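Aryl variation on the saturated ring carbon of the shared core

A few compounds are considered here, and "the series" means these few. Any claim that something is new, unique, unknown or untested is made for them only; others in the source may bear on it.

Measured so far, with growth inhibition on NCI-H460 cells:
compound 1 `Cc1cc(O)c(C2=NN(c3ccc(S(N)(=O)=O)cc3)C(c3ccccc3O)C2)cc1Cl`, 2060 nM
compound 2 `Cc1cc(O)c(C2=NN(c3ccc(S(N)(=O)=O)cc3)C(c3ccccc3Cl)C2)cc1Cl`, 2160 nM
compound 3 `COc1ccc(C2CC(c3cc(Cl)c(C)cc3O)=NN2c2ccc(S(N)(=O)=O)cc2)cc1OC`, 2500 nM

In a functional assay on NCI-H460 cells (Homo sapiens) for antiproliferative activity, with a stated time of 48 h (on this read-out lower numbers stand for stronger inhibition of growth and higher numbers for weaker inhibition of growth), compound 3 stands alongside compounds 1 and 2: a 1.2-fold higher number from compound 1 to compound 3 (0.08 log units; within the scatter) and a 1.2-fold higher number from compound 2 to compound 3 (0.06 log units; within the scatter). Compound 1 and compound 2 are likewise close to each other, a 1.0-fold higher number from compound 1 to compound 2 (0.02 log units; within the scatter). Across these three compounds, swapping the aryl group on the saturated ring carbon has not moved the number beyond the scatter.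

Compound 4 `COc1ccc(C2CC(c3cc(Cl)c(C)cc3O)=NN2c2ccc(S(N)(=O)=O)cc2)c(OC)c1OC` is the next member and has not yet been measured in this assay. The change from compound 3 is methoxy in place of hydrogen on an aromatic carbon; cut one bond further out it reads 3,4-dimethoxyphenyl to 2,3,4-trimethoxyphenyl. Within the data shown here, the steps that bear on it are those that alter this same aryl group, from compound 1 to compound 3 and from compound 2 to compound 3, both within the scatter. Among the measured compounds shown here, no measured step shows an added methoxy on this ring alone, so the expectation rests on the general flatness of the aryl variation here. The step to compound 4 is therefore expected to be a 1.0-fold higher number from compound 3 to compound 4 (0.02 log units; within the scatter), not beyond the scatter in either direction. For compound 4 the estimated value in this assay is 2600 nM, in the range 1300 nM to 5200 nM.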

Compound 4, concentration for 50% growth inhibition: 2120 nM
The estimate for compound 4 lay 1.2-fold (0.09 log units) above the measured number; the measured number falls inside the stated range.
By their numbers in this assay, from the lowest: compounds 1, 4, 2 and 3 (each within the scatter of the next).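

In this assay, among these compounds, methoxy in place of hydrogen on an aromatic carbon, ortho to a large group and ortho to a methoxy group, is the first change that adds one group to this aryl ring and nothing else, and it stays within the scatter (a 1.2-fold lower number from compound 3 to compound 4 (0.07 log units; within the scatter)). The 2,3,4-trimethoxyphenyl group also gives a number within the scatter of those with the 2-chlorophenyl group (a 1.0-fold lower number from compound 2 to compound 4 (0.01 log units; within the scatter)) and the 2-hydroxyphenyl group (a 1.0-fold higher number from compound 1 to compound 4 (0.01 log units; within the scatter)), so all four aryl groups on the saturated ring carbon now sit within the scatter of one another in this growth read-out. Nothing at hand accounts for this flatness or separates the contribution of any one group on the ring.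

As far as these compounds go, all four compounds carry a substituted phenyl group at this carbon, so it remains open whether the flatness would hold with an amine or a carboxylic acid on that ring, or with a longer chain in place of the ring. The rest of the shared core is the same throughout, so these compounds do not show whether changes elsewhere on it would move the number.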